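The source may hold more compounds than are shown below. What is called first, only, known or untested is meant among the compounds shown, and "the series" means these compounds.

Measured compounds:
compound 1 `Cc1cc(Cl)cc(Cl)c1S(=O)(=O)N1CCC(N2CCC(C)CC2)CC1` — 0.6 nM
compound 2 `CC1CCN(C2CCN(S(=O)(=O)c3cccc(C(F)(F)F)c3)CC2)CC1` — > 5000 nM

In a functional assay on DLD-1 cells (Homo sapiens) for antiproliferative activity, read by CellTiter-Glo, with a stated time of 72 h (on this read-out higher numbers stand for weaker inhibition and lower numbers for stronger inhibition), compound 1 gives 0.6 nM. Compound 2 returns only > 5000 nM, which is a limit of the assay and not a number, so compound 2 stands at the limit of > 5000 nM in this assay, at which 1 of the 2 values shown sits. Compound 3 `CC1CCN(C2CCN(S(=O)(=O)c3cccc(-c4ccc5ccccc5c4)c3)CC2)CC1` differs from compound 2 by naphthalen-2-yl in place of trifluoromethyl on an aromatic carbon. Since compound 2 offers only a limit, this step cannot be set against any measured step. The account expects an at least 5.0-fold lower number from compound 2 to compound 3 (0.69 log units; beyond the scatter) in the direction of stronger inhibition, with wide uncertainty. Compound 3 is estimated at 1000 nM, between 100 nM and 10000 nM.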

Compound 3, half-maximal inhibitory concentration: 2 nM
Estimate against measurement, compound 3: 500-fold (2.70 log units) above; the whole stated range lies above it.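

In this assay, naphthalen-2-yl in place of trifluoromethyl on this aromatic carbon gives an at least 2500-fold lower number from compound 2 to compound 3 (3.39 log units; beyond the scatter), so this position, on the ring that carries the sulfonyl group, can hold a far larger group with strong inhibition retained. The size of the step has only a lower bound, since its starting point for compound 2 is a limit and not a number: the limit of > 5000 nM in this assay, at which 1 of the 3 values shown sits.

What the compounds shown leave open is whether both rings of naphthalen-2-yl are needed. A single phenyl ring, a methoxy group or an amine at this position would bear on that.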